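Solubility of a Carboxyindole Analogue Estimated from Two Measurements

The source may report more compounds than this note shows. Statements on the series, on what has been measured and on what is new or still open speak of the compounds shown alone.

Compound 1, `OC[C@@H](O[C@H]1CCCN(Cc2ncc[nH]2)[C@H]1c1ccccc1)c1cc(Cl)cc(Cl)c1`, was tested in a physicochemical assay for solubility, read by HPLC, with a stated time of 24 h, at pH 7; a higher number here means a more soluble compound, a lower number a less soluble compound. In this assay compound 1 gives 60000 nM, the lower of the two numbers available. Its nearest neighbour is compound 2, `Clc1cc(Cl)cc(CO[C@H]2CCCN(Cc3ncc[nH]3)[C@H]2c2ccccc2)c1`, which in this assay gives 120000 nM; the step of a 2.0-fold higher number from compound 1 to compound 2 (0.30 log units; within the scatter) comes from swapping hydrogen for hydroxymethyl on a saturated chain carbon bound to an aromatic carbon and an oxygen on a saturated carbon.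

Compound 3, `O=C(O)c1ccc2c(CN3CCC[C@H](O[C@H](CO)c4cc(Cl)cc(Cl)c4)[C@@H]3c3ccccc3)c[nH]c2c1`, has not yet been measured. It differs from compound 1 at a different site: 6-carboxy-1H-indol-3-yl in place of 1H-imidazol-2-yl on a saturated chain carbon bound to an amine nitrogen in a ring. Within the data shown here, the one measured step concerns another part of the molecule and a far smaller exchange, so it does not bear directly on this change. Among the measured compounds shown here, no compound in the set carries a carboxy group or an indole, so the expectation rests on the size of the change alone and is uncertain.

Compound 3 is therefore expected to give roughly 40000 nM, in a wide range from 8000 nM to 200000 nM. This estimate means a step of a 1.5-fold lower number from compound 1 to compound 3 (0.18 log units; within the scatter), which is expected to fall within the scatter.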

Compound 3, solubility: 128000 nM
Beside the measured number, compound 3's estimate is 3.2-fold (0.51 log units) below it; the measured number falls inside the stated range.
By their numbers in this assay, from the lowest: compounds 1, 2 and 3 (each within the scatter of the next, the first and the last beyond it).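

Among these compounds, at the place printed as a saturated chain carbon bound to an amine nitrogen in a ring, compound 3 gives the first reading of any change at this site: in this assay, putting 6-carboxy-1H-indol-3-yl in place of 1H-imidazol-2-yl gives a 2.1-fold higher number from compound 1 to compound 3 (0.33 log units; beyond the scatter), a modest step. Among the compounds shown here, the only earlier step, a 2.0-fold higher number from compound 1 to compound 2 (0.30 log units; within the scatter), concerned the hydroxymethyl at another site and stayed within the scatter, whereas this one shows that a group of 12 heavy atoms with two aromatic rings can replace one of 5 heavy atoms with one ring without the number falling. No measurement here explains the step or says which part of the entering group lies behind it.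

The entering group brings an indole and a carboxy group in a single exchange, so the two cannot be told apart here; a plain 1H-indol-3-yl or a methyl ester in place of the carboxy group would separate them. From the compounds shown here alone, it also remains open whether the same exchange would give a step of similar size on compound 2, which lacks the hydroxymethyl.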